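A carbamoyl swap at one aromatic carbon

The source may report more compounds than this note shows. Statements on the series, on what has been measured and on what is new or still open speak of the compounds shown alone.

compound 1 `Cc1cc2c(NS(C)(=O)=O)cccc2n1-c1nc2c(c(NCc3cccc(O)c3)n1)CCC2`: 800 nM
compound 2 `C=CC(=O)Nc1cccc2c1cc(C)n2-c1nc2c(c(NCc3cccc(O)c3)n1)CCC2`: 1200 nM
compound 3 `Cc1cc2c(C(=N)NO)cccc2n1-c1nc2c(c(NCc3cccc(O)c3)n1)CCC2`: 1100 nM

In a functional assay on HCT-116 cells (Homo sapiens) for inhibition, read by luminescence and CellTiter-Glo, with a stated time of 72 h (a lower number here means a stronger inhibitor, a higher number a weaker inhibitor), compound 3 gives 1100 nM and stands within the scatter of the other two compounds, so the three cannot be ranked. The next compound, compound 4 `Cc1cc2c(C(N)=O)cccc2n1-c1nc2c(c(NCc3cccc(O)c3)n1)CCC2`, carries one change from compound 3: a group of 3 heavy atoms (1 carbon, 1 nitrogen, 1 oxygen; no ring) in place of a group of 4 heavy atoms (1 carbon, 2 nitrogen, 1 oxygen; no ring), on an aromatic carbon, with carbamoyl entering on an aromatic carbon of a six-membered aromatic ring of carbon only. The measured compounds differ from one another at that same carbon, so their steps bear on this change: a 1.5-fold higher number from compound 1 to compound 2 (0.18 log units; within the scatter), then a 1.4-fold higher number from compound 1 to compound 3 (0.14 log units; within the scatter), and a 1.1-fold lower number from compound 2 to compound 3 (0.04 log units; within the scatter). All three lie within the scatter. Among the compounds with values here, none of the measured compounds carries carbamoyl, so this evidence is only indirect, and three compounds are few. The expected step is a 1.1-fold lower number from compound 3 to compound 4 (0.04 log units; within the scatter), and it is not expected to go beyond the scatter. For compound 4 the estimated value is 1000 nM, with an expected range from 450 nM to 2200 nM.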

Compound 4, half-maximal inhibitory concentration: 400 nM
Compound 4: middle estimate off by 2.5-fold (0.40 log units), on the high side; the measured number lies below the stated range.
By their numbers in this assay, from the lowest: compounds 4, 1, 3 and 2 (each within the scatter of the next, the first and the last beyond it).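

In this assay, within the data shown here, carbamoyl is the first group at this aromatic carbon to give a difference beyond the scatter, both against the group it replaces (a 2.8-fold lower number from compound 3 to compound 4 (0.44 log units; beyond the scatter)) and against (vinylcarbonyl)amino (a 3.0-fold lower number from compound 2 to compound 4 (0.48 log units; beyond the scatter)), whereas the three earlier groups could not be told apart. Against methanesulfonamido the step stays within the scatter (a 2.0-fold lower number from compound 1 to compound 4 (0.30 log units; within the scatter)), so carbamoyl cannot be set apart from every group tried here. Nothing in the data explains these differences.

What the compounds leave open is whether a carboxylic acid, a nitrile or an N-methyl amide at this carbon would give a number like that of carbamoyl. Going by these compounds, all four compounds also share the rest of their structure, so it remains unknown whether the step would hold with carbamoyl on a different core.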